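The compounds below may be only part of what the source reports. "The series", "measured", "known", "first", "only" and "open" are said of these compounds alone.

Three compounds share one core and differ only in the group attached to a single aromatic carbon. Compound 1 `O=C(NCCO)c1cccc(Nc2ncc(F)c(Nc3ccc(F)cc3)n2)c1` carries a (2-hydroxyethyl)carbamoyl group there; in a functional assay on A549 cells (Homo sapiens) for antiproliferative activity, read by sulforhodamine B assay, with a stated time of 3 days (on this read-out lower numbers stand for stronger inhibition of growth and higher numbers for weaker inhibition of growth), compound 1 gives 11900 nM. Compound 2 `O=C(Nc1cc(Cl)cc(Cl)c1)c1cccc(Nc2ncc(F)c(Nc3ccc(F)cc3)n2)c1` carries a (3,5-dichlorophenyl)carbamoyl group instead, and in this assay compound 2 gives 17500 nM; the step of a 1.5-fold higher number from compound 1 to compound 2 (0.17 log units; within the scatter). Compound 3 `O=C(Nc1cccc(Nc2ncc(F)c(Nc3ccc(F)cc3)n2)c1)c1ccncc1` turns the amide around, carrying a ((pyridin-4-yl)carbonyl)amino group; in this assay compound 3 gives 1650 nM, the lowest of the three numbers. The steps of a 7.2-fold lower number from compound 1 to compound 3 (0.86 log units; beyond the scatter) and an 11-fold lower number from compound 2 to compound 3 (1.03 log units; beyond the scatter) are both clear gains.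

Compound 4 `COCC(=O)Nc1cccc(Nc2ncc(F)c(Nc3ccc(F)cc3)n2)c1` keeps the turned-around amide but changes its acyl part: methoxymethyl in place of pyridin-4-yl on a carbonyl carbon. For the measured compounds named here, no measured step swaps a ring for a short chain on this carbonyl carbon, so the expectation rests on analogy. The nearest hint is compound 1, which also carries a small oxygen-bearing chain on its amide and gives 11900 nM, well weaker than compound 3. A moderate loss is therefore expected, a 3.0-fold higher number from compound 3 to compound 4 (0.48 log units; beyond the scatter). Compound 4 is estimated at 5000 nM, within a range of 1500 nM to 16000 nM.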

Compound 4, concentration for 50% growth inhibition: 2050 nM
The estimate for compound 4 lay 2.4-fold (0.39 log units) above the measured number, within the range that was stated.
By their numbers in this assay, from the lowest: compounds 3 and 4 (each within the scatter of the next); then compounds 1 and 2 (each within the scatter of the next).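

In this assay, replacing pyridin-4-yl with methoxymethyl on the carbonyl carbon makes no difference beyond the scatter (a 1.2-fold higher number from compound 3 to compound 4 (0.09 log units; within the scatter)), so a short chain without a ring does as well here as this aromatic ring. The turned-around amide also stays ahead of the two earlier amides with this second acyl part (an 8.5-fold lower number from compound 2 to compound 4 (0.93 log units; beyond the scatter); a 5.8-fold lower number from compound 1 to compound 4 (0.76 log units; beyond the scatter)), which shows that the better numbers among these four compounds are not tied to pyridin-4-yl alone. No measured evidence here explains why these two different acyl parts give such similar numbers.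

On these data alone, whether a longer chain, a carboxylic acid or an amine such as dimethylaminomethyl on this carbonyl carbon would give similar numbers remains open. Also open, as far as these compounds go, is how a 3,5-dichlorophenyl group would behave on the turned-around amide.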